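The source may hold more compounds than are shown below. What is called first, only, known or untested is meant among the compounds shown, and "the series" means these compounds.

Among the compounds with values here, compound 2 `O=c1[nH]/c(=N\OCCCc2ccc([N+](=O)[O-])cc2)ccn1[C@@H]1O[C@H](COP(=O)(O)OP(=O)(O)OP(=O)(O)O)[C@@H](O)[C@H]1O` gives the lower of the two numbers measured so far in a functional assay on 1321-N1 cells for agonist activity at P2Y purinoceptor 4 (Homo sapiens), read by scintillation counting and inositol phosphate accumulation; a higher number here means that more compound is needed for the effect, a lower number that less compound is needed: compound 2 gives 84 nM, while compound 1 `O=c1[nH]/c(=N\OCCCc2cccc(I)c2)ccn1[C@@H]1O[C@H](COP(=O)(O)OP(=O)(O)OP(=O)(O)O)[C@@H](O)[C@H]1O` gives 114 nM. The step between them, a 1.4-fold lower number from compound 1 to compound 2 (0.13 log units; within the scatter), lies within the scatter, so the two compounds cannot be set apart on these numbers.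

Compound 3 `O=c1[nH]/c(=N\OCCCc2ccncc2)ccn1[C@@H]1O[C@H](COP(=O)(O)OP(=O)(O)OP(=O)(O)O)[C@@H](O)[C@H]1O` has not yet been measured. It differs from compound 2 in one place: pyridin-4-yl in place of 4-nitrophenyl on a saturated chain carbon, three bonds along the chain from an oxygen. Within the data shown here, the only step measured so far, from compound 1 to compound 2, exchanged one aromatic ring for another on the same saturated chain carbon and left the number essentially unchanged, but it does not involve a pyridin-4-yl group, so it bears only loosely on this change. With no step beyond the scatter in hand, no change beyond the scatter is expected, and compound 3 is estimated at 100 nM in this assay, in a range from 35 nM to 300 nM, corresponding to an expected step of a 1.2-fold higher number from compound 2 to compound 3 (0.08 log units; within the scatter).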

Compound 3, half-maximal effective concentration: 250 nM
Compound 3: middle estimate off by 2.5-fold (0.40 log units), on the low side; low and high end bracket the measured number.
By their numbers in this assay, from the lowest: compounds 2 and 1 (each within the scatter of the next); then compound 3.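

In this assay, exchanging one aromatic ring for another at this position is not always without effect: replacing 4-nitrophenyl with pyridin-4-yl gives a 3.0-fold higher number from compound 2 to compound 3 (0.47 log units; beyond the scatter), and replacing 3-iodophenyl with pyridin-4-yl gives a 2.2-fold higher number from compound 1 to compound 3 (0.34 log units; beyond the scatter). Both steps are modest, but they show that the group on the chain can shift the number, which the step between compound 1 and compound 2 did not show. Nothing available explains this shift.

Each step brings in a ring with one hetero atom and also removes a ring substituent, so these compounds cannot separate the two changes. A plain phenyl group on the same chain would separate them, while a longer chain carrying pyridin-4-yl would test whether the distance from the oxygen matters.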